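The compounds below may be only part of what the source reports. "The series", "measured", "known", "first", "only" and "open" are said of these compounds alone.

The series shares one core and varies the diamine and the aryl group attached to its nitrogen; all were examined in a functional assay on CHO-K1 cells for antagonist activity at C-X-C chemokine receptor type 3 (Homo sapiens), read by FLIPR and calcium flux; a lower number here means a stronger inhibitor, a higher number a weaker inhibitor. Compound 1 `CC1(C)[C@@H]2CC[C@@]1(CS(=O)(=O)N1CCN(c3ccc(Br)cn3)CC1)C(=O)C2` gives 1580 nM in this assay, the lowest of the two numbers that were reported. Compound 2 `CC1(C)[C@@H]2CC[C@@]1(CS(=O)(=O)N1CCCN(c3ccc(C(F)(F)F)cn3)CC1)C(=O)C2`, with a seven-membered diamine ring and a 5-(trifluoromethyl)pyridin-2-yl group, gives 6310 nM, a gap that lies beyond the scatter and places compound 1 ahead. Compound 3 `CN(CCN(C)S(=O)(=O)C[C@]12CC[C@H](CC1=O)C2(C)C)c1ccc(C(F)(F)F)cn1`, whose diamine is an open chain, reaches only a limit of the measurement, > 31600 nM. For that compound the limit of > 31600 nM in this assay, at which 1 of the 3 values shown sits, applies.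

Compound 4 `CC1(C)[C@@H]2CC[C@@]1(CS(=O)(=O)N1CCN(c3ncc(C(F)(F)F)cn3)CC1)C(=O)C2` has not yet been measured. It differs from compound 1 in one place: 5-(trifluoromethyl)pyrimidin-2-yl in place of 5-bromopyridin-2-yl on an amine nitrogen in a ring. Going by the values given here, the six-membered diamine ring and its link to the shared core remain exactly those of compound 1, and no step between two measured compounds covers this kind of aryl exchange. The change is expected to shift the number only a little, if at all, and more likely toward a weaker inhibitor than a stronger one. Compound 4 is therefore estimated to give 2500 nM in this assay, with a plausible range from 800 nM to 8000 nM. The expected step, a 1.6-fold higher number from compound 1 to compound 4 (0.20 log units; within the scatter), is estimated to stay close to the usual scatter.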

Compound 4, half-maximal inhibitory concentration: 316 nM
The estimate for compound 4 lay 7.9-fold (0.90 log units) above the measured number, outside the stated range (below it).
By their numbers in this assay, from the lowest: compound 4; then compound 1; then compound 2. At a limit, above all of these: compound 3.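

With the diamine and the shared core held constant, the aryl group on the amine nitrogen clearly matters in this assay: exchanging 5-bromopyridin-2-yl for 5-(trifluoromethyl)pyrimidin-2-yl gives a 5.0-fold lower number from compound 1 to compound 4 (0.70 log units; beyond the scatter). Going by these compounds alone, no earlier pair of measured compounds differed in one place only, so the aryl group could not yet be read apart from the diamine, and even this exchange alters two features together, adding a hetero atom to the aromatic ring and putting trifluoromethyl where bromine stood. Nothing measured here bears on the reason for the step.

On these data alone, whether the added ring nitrogen or the trifluoromethyl group accounts for the step remains open, as does how 5-(trifluoromethyl)pyridin-2-yl would read on the six-membered diamine. It is equally unknown how a nitrile or a methoxy group would read in place of the trifluoromethyl group on the pyrimidine ring, and whether the 5-(trifluoromethyl)pyrimidin-2-yl group would give a similar step on the seven-membered diamine.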